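Cyclopropyl amide from the morpholine amide: notes

The compounds below may be only part of what the source reports. "The series", "measured", "known", "first", "only" and "open" are said of these compounds alone.

In a functional assay on KB cells (Homo sapiens) for inhibition, read by sulforhodamine B assay, with a stated time of 72 h (on this read-out higher numbers stand for weaker inhibition of growth and lower numbers for stronger inhibition of growth), compound 1, `CNC(=O)/C=C/c1ccncc1-c1ccc2ccccc2c1`, gives > 10000 nM, which is a limit. Compound 2, `O=C(O)/C=C/c1ccncc1-c1ccc2ccccc2c1`, gives > 10000 nM, also a limit. Compound 3, `O=C(/C=C/c1ccncc1-c1ccc2ccccc2c1)N1CCOCC1`, gives > 10000 nM, again a limit and not a number. Compound 3 therefore has no measured position of its own within the series, which stands at the limit of > 10000 nM in this assay, at which 3 of the 3 values shown sit.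

Compound 4, `O=C(/C=C/c1ccncc1-c1ccc2ccccc2c1)NC1CC1`, carries cyclopropylamino in place of morpholin-4-yl on a carbonyl carbon.

Among the compounds with values here, the steps that bear on this change are a step that the two limits leave unreadable from compound 1 to compound 3 and a step that the two limits leave unreadable from compound 2 to compound 3, and the remaining one is a step that the two limits leave unreadable from compound 1 to compound 2. None of them gives a size to carry over. The expectation rests on compound 1, which holds methylamino on a carbonyl carbon and gives the limit > 10000 nM. No change beyond the scatter is expected in this assay, and a further limit is the likeliest report. The expected step is a number no higher from compound 3 to compound 4 (the limit leaves the size open). For compound 4 the estimate is 10000 nM, with an expected range from 4000 nM to 30000 nM.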

Compound 4, concentration for 50% growth inhibition: 6050 nM
Beside the measured number, compound 4's estimate is 1.7-fold (0.22 log units) above it; measured number inside the range.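

In this assay compound 4 is the only compound shown that reads as a number, and the other three stay at one limit: the limit of > 10000 nM in this assay, at which 3 of the 4 values shown sit.

Cyclopropylamino in place of morpholin-4-yl gives an at least 1.6-fold lower number from compound 3 to compound 4 (0.21 log units; that floor lies within the scatter), in place of hydroxy it gives an at least 1.6-fold lower number from compound 2 to compound 4 (0.21 log units; that floor lies within the scatter), and cyclopropyl in place of methyl on the amide-type nitrogen gives an at least 1.6-fold lower number from compound 1 to compound 4 (0.21 log units; that floor lies within the scatter). Within the data shown here, a reading can therefore be had with a substituent on this carbonyl carbon, but no step shows a change beyond the scatter, and the steps among compound 1, compound 2 and compound 3 cannot be read.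

On these data alone, whether cyclobutylamino or isopropylamino on the same carbonyl carbon would give a reading clearly apart from compound 4 stays open. So does whether a saturated chain in place of the double-bonded chain would keep a reading at all.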